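Removing a Chloro Group from a Weak Antiproliferative Series

The source may report more compounds than this note shows. Statements on the series, on what has been measured and on what is new or still open speak of the compounds shown alone.

Three compounds sharing one core were tested in a functional assay on EKVX cells (Homo sapiens) for antiproliferative activity; on this read-out lower numbers stand for stronger inhibition of growth and higher numbers for weaker inhibition of growth. Compound 1 `COc1ccc(-n2cc(-c3ccc(Cl)cc3)[nH]c2=S)cc1Cl` gives 39800 nM. Compound 2 `COc1cc(-n2cc(-c3ccc(Cl)cc3)[nH]c2=O)cc(OC)c1OC` gives 31600 nM, the lowest number of the three, though both other compounds sit within the scatter of it. Compound 3 `COc1ccc(-n2cc(-c3ccc(OC)c(OC)c3)[nH]c2=S)cc1Cl` gives 39800 nM. Going by the values given here, all three inhibit growth only weakly, and no pair among them is separated beyond the scatter. Compound 4 `COc1cc(-n2cc(-c3ccccc3)[nH]c2=O)cc(OC)c1OC` has not yet been measured; it differs from compound 2 as follows: hydrogen in place of chloro on an aromatic carbon. Among the compounds with values here, no measured pair shows this particular change, so there is no measured step to lean on. A step of a 1.3-fold higher number from compound 2 to compound 4 (0.10 log units; within the scatter) is expected, no larger than the scatter, leaning slightly toward weaker inhibition. Compound 4 is estimated at 40000 nM, with a range from 15000 nM to 100000 nM.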

Compound 4, concentration for 50% growth inhibition: 25100 nM
Compound 4: the middle estimate sits 1.6-fold (0.20 log units) above what was measured, and the stated range covers the measured number.
By their numbers in this assay, from the lowest: compounds 4, 2, 1 and 3 (each within the scatter of the next).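

In this assay, going by these compounds alone, going from 4-chlorophenyl to phenyl gives a 1.3-fold lower number from compound 2 to compound 4 (0.10 log units; within the scatter) and is the first change in one place that can be read in this set. For this pair, the chloro group para to a large group can be replaced by hydrogen with no difference beyond the scatter, and growth inhibition stays weak. Nothing measured here offers an explanation for this result.

From the compounds shown here alone, whether an amine or a carboxylic acid at this position would give a clearly different number remains open. So does whether the same change would behave alike in compound 1 .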